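Swapping an Ethyl Group for Ethylamino on a Pyridine Ether

This account rests on a few compounds, and the source may have more. Where it says the series, first, only, none or still open, it means among the compounds named here.

Of the compounds shown here, three have been measured in an assay on membranes from brain for displacement of a labelled ligand from Neuronal acetylcholine receptor; alpha4/beta2 (Rattus norvegicus); on this read-out higher numbers stand for weaker inhibition and lower numbers for stronger inhibition. Compound 1 `CN1CCC[C@H]1COc1cnccc1Br` gives 28 nM, compound 3 `CN1CCC[C@H]1COc1cc(Br)c[n+]([O-])c1` gives 34.8 nM, and compound 2 `CCc1cncc(OC[C@@H]2CCCN2C)c1` gives 0.32 nM. Compound 2 therefore stands at the lowest number of the three, with compound 1 and compound 3 both well above it. Both of these gaps lie beyond the scatter of repeated measurements. Compound 2 is thus the strongest inhibitor among the measured set.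

The untested compound 4 `CCNc1cncc(OC[C@@H]2CCCN2C)c1` is derived from compound 2 by one change: ethylamino in place of ethyl on an aromatic carbon. Within the data shown here, no measured pair in this set shows the effect of such a swap, so the direction of the step can only be guessed. Because compound 2 already gives 0.32 nM, a modest move toward a higher number is expected, possibly within the scatter, possibly a little beyond it. Compound 4 is estimated to give 1.2 nM, within a range from 0.25 nM to 6 nM. This corresponds to an expected step of a 3.8-fold higher number from compound 2 to compound 4 (0.57 log units; beyond the scatter).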

Compound 4, inhibition constant: 3.7 nM
The estimate for compound 4 lay 3.1-fold (0.49 log units) below the measured number; the measured number falls inside the stated range.
By their numbers in this assay, from the lowest: compound 2; then compound 4; then compounds 1 and 3 (each within the scatter of the next).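

In this assay, among these compounds, the swap of ethyl for ethylamino on this aromatic carbon, two atoms from the ring nitrogen, gives a 12-fold higher number from compound 2 to compound 4 (1.06 log units; beyond the scatter) and is the first single change that can be read in this set. The step shows that this position is sensitive: exchanging one small chain for another of nearly the same size, which adds a nitrogen and a hydrogen-bond donor, weakens inhibition well beyond the scatter. Nothing measured here explains why the number moves.

The compounds shown leave open whether another group on this carbon, such as a plain amine, a methoxy group or a longer chain like propyl, would stay closer to compound 2. They also leave open whether the same swap would have as large an effect on a different core.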